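The compounds below may be only part of what the source reports. "The series", "measured", "known", "first", "only" and "open" are said of these compounds alone.

Compound 1 `CCC(=O)N(C)c1ccc2[nH]c(-c3n[nH]c4ccccc34)cc2n1`: in a functional assay on A549 cells (Homo sapiens) for antiproliferative activity, read by MTT assay, with a stated time of 72 h (a lower number here means a stronger inhibitor, a higher number a weaker inhibitor), compound 1 gives 15700 nM
Compound 2 `CN(C(=O)c1ccccc1)c1ccc2[nH]c(-c3n[nH]c4ccccc34)cc2n1`: in this assay compound 2 gives 13800 nM

Compound 2 and compound 1 cannot be told apart on these numbers: a 1.1-fold lower number from compound 1 to compound 2 (0.06 log units; within the scatter), a change from ethyl to phenyl on the carbonyl carbon.

Compound 3 `CN(C(=O)c1ccc(F)cc1)c1ccc2[nH]c(-c3n[nH]c4ccccc34)cc2n1` differs from compound 2 by fluoro in place of hydrogen on an aromatic carbon. Within the data shown here, no measured step touches this ring; the only step known, a 1.1-fold lower number from compound 1 to compound 2 (0.06 log units; within the scatter), replaced the whole group on the carbonyl and still stayed within the scatter. The expected step of a 1.1-fold lower number from compound 2 to compound 3 (0.03 log units; within the scatter) is therefore small, with no clear direction. Compound 3 is estimated at 13000 nM, with a range from 6000 nM to 30000 nM.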

Compound 3, half-maximal inhibitory concentration: 9650 nM
Estimate against measurement, compound 3: 1.3-fold (0.13 log units) above, within the range that was stated.
By their numbers in this assay, from the lowest: compounds 3, 2 and 1 (each within the scatter of the next).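

In this assay, among these compounds, fluoro on the phenyl ring, para to a large group, gives the first measured step at this ring (a 1.4-fold lower number from compound 2 to compound 3 (0.16 log units; within the scatter)). Replacing ethyl on the carbonyl carbon with 4-fluorophenyl also leaves the compounds inseparable (a 1.6-fold lower number from compound 1 to compound 3 (0.21 log units; within the scatter)), so neither change yet shows that this part of the molecule matters in this assay. No supporting measurement bears on these small steps. On these data alone, whether an amine or a carboxylic acid at this ring position would give a step beyond the scatter remains open. So does the effect of a longer chain on the carbonyl.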